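The compounds below may be only part of what the source reports. "The series", "measured", "known", "first", "only" and "open" are said of these compounds alone.

Compound 1 `CC(C)N(Cc1cccc(OCCCCCC(=O)O)c1)C(=O)c1ccc(-c2cccc(-c3ccccc3)c2)cc1` — an ADME assay on BJ cells (Homo sapiens) for cytotoxicity, read by CellTiter-Glo and resazurin assay, with a stated time of 72 h; a lower number here means that less compound is needed, a higher number that more compound is needed for the effect: > 26000 nM, a limit of the assay.
Compound 2 `COc1cc(OC)cc(-c2ccc(C(=O)N(Cc3cccc(OCCCCCC(=O)O)c3)C(C)C)cc2)c1` — this assay: > 26000 nM, also a limit of the assay.

Compound 2 stands where compound 1 stands: in this assay compound 2 reaches only a limit, so no number is known for it. Among the compounds with values here, the one measured step, a step that the two limits leave unreadable from compound 1 to compound 2, is therefore unreadable; what both compounds share is described by the limit of > 26000 nM in this assay, at which 2 of the 2 values shown sit, and nothing more can be drawn from it.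

The next compound is compound 3 `CC(C)N(Cc1cccc(OCCCCCC(=O)O)c1)C(=O)c1ccc(-c2cccc(Cl)c2)cc1`. It differs from compound 2 in one place: 3-chlorophenyl in place of 3,5-dimethoxyphenyl on an aromatic carbon. Within the data shown here, the only measured step that bears on this position is the one from compound 1 to compound 2, and its size is not readable, so the change at this position gives no direction to read off. The expectation for compound 3 rests on the two measured compounds sitting at the limit, and the step that the limit leaves unreadable from compound 2 to compound 3 is expected to be none beyond the scatter. Compound 3 is estimated at 30000 nM, with a range from 13000 nM to 70000 nM, most likely again reported only as a limit.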

Compound 3, half-maximal effective concentration: > 21900 nM
Compound 3 ended at the assay's limit (the forecaster's own chance of this, stated with the estimate: 75%); the middle value lies beyond the limit too.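

Compound 3 gives > 21900 nM in this assay as a limit of the assay, not as a number. Within the data shown here, compound 1, compound 2 and compound 3 all stand at limits, so no step among them can be read. What they leave open is whether any group on this aromatic carbon gives a readable value in this assay at all.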